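Methyl in place of chloro: what to expect for compound 4

The source may report more compounds than this note shows. Statements on the series, on what has been measured and on what is new or still open speak of the compounds shown alone.

Compound 1 `Cc1ccc(NC(=S)N/N=C2\C(=O)Nc3ccc(F)cc32)cc1` gives 8200 nM in a functional assay on L1210 cells (Mus musculus), with a stated time of 48 h; on this read-out lower numbers stand for stronger inhibition and higher numbers for weaker inhibition.
Compound 2 `O=C1Nc2ccc(F)cc2/C1=N/NC(=S)Nc1ccc(Cl)cc1` gives 34000 nM.
Compound 3 `O=C1/C(=N\NC(=S)Nc2ccc(Cl)cc2)c2cc(F)ccc2N1Cc1ccc(F)cc1` gives 154000 nM.

Compound 3 stands highest of the three numbers, above compound 2 after the change a 4.5-fold higher number from compound 2 to compound 3 (0.66 log units; beyond the scatter), and far above compound 1. Compound 4 `Cc1ccc(NC(=S)N/N=C2\C(=O)N(Cc3ccc(F)cc3)c3ccc(F)cc32)cc1` differs from compound 3 in one place: methyl in place of chloro on an aromatic carbon. Going by the values given here, the only measured step that bears on this is the reverse exchange, a 4.1-fold higher number from compound 1 to compound 2 (0.62 log units; beyond the scatter), a modest move beyond the scatter. Undoing it should move the number the other way by a similar amount, so a modest fall in this assay is expected, a 4.1-fold lower number from compound 3 to compound 4 (0.61 log units; beyond the scatter). Compound 4 is therefore estimated at 38000 nM, within a range of 15000 nM to 100000 nM.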

Compound 4, half-maximal inhibitory concentration: 6200 nM
Estimate against measurement, compound 4: 6.1-fold (0.79 log units) above; measured number below the stated range.
By their numbers in this assay, from the lowest: compounds 4 and 1 (each within the scatter of the next); then compound 2; then compound 3.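

Once the 4-fluorobenzyl group sits on the ring nitrogen, methyl in place of chloro brings a 25-fold lower number from compound 3 to compound 4 (1.40 log units; beyond the scatter) and so counts for far more than it did on the core of compound 1: the same change on two cores in this assay, a 4.1-fold higher number (0.62 log units; beyond the scatter) from compound 1 to compound 2 and a 25-fold higher number (1.40 log units; beyond the scatter) from compound 4 to compound 3, 6.0-fold (0.78 log units) apart, beyond the scatter of two such steps. With methyl on the aromatic ring, adding the 4-fluorobenzyl group gives a 1.3-fold lower number from compound 1 to compound 4 (0.12 log units; within the scatter) and no longer weakens inhibition as it did with chloro: the same change on two cores in this assay, a 4.5-fold higher number (0.66 log units; beyond the scatter) from compound 2 to compound 3 and a 1.3-fold lower number (0.12 log units; within the scatter) from compound 1 to compound 4, 6.0-fold (0.78 log units) apart, beyond the scatter of two such steps. The two changes therefore cannot be read independently of each other. As far as these compounds go, it remains open whether this dependence extends to a methoxy group or an amine on the same aromatic carbon, or to a longer chain on the ring nitrogen.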